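A few compounds are considered here, and "the series" means these few. Any claim that something is new, unique, unknown or untested is made for them only; others in the source may bear on it.

Compound 2 `COc1cccc(OC)c1OCCNCCOc1ccccc1OCc1ccc(C)cc1` and compound 1 `COc1cccc(OC)c1OCCNCCOc1ccccc1OCc1ccccc1C` share one core and differ only in the group on the saturated chain carbon bound to an oxygen on an aromatic ring. In a functional assay on PC-3 cells (Homo sapiens) for cytotoxicity, read by sulforhodamine B assay (on this read-out lower numbers stand for stronger inhibition of growth and higher numbers for weaker inhibition of growth), compound 2 gives 27500 nM, the lowest of the two numbers recorded; in this assay compound 1 gives 33900 nM. Within the data shown here, the move a 1.2-fold lower number from compound 1 to compound 2 (0.09 log units; within the scatter) is the only measured step, and it stays within the scatter.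

Compound 3 `COc1cccc(OC)c1OCCNCCOc1ccccc1OCc1ccccc1[N+](=O)[O-]` carries 2-nitrophenyl in place of 4-methylphenyl on a saturated chain carbon bound to an oxygen on an aromatic ring. Among the measured compounds shown here, no measured pair touches a nitro group, so the single step to hand, from compound 1 to compound 2, bears on this change only in that it shows the two benzyl ethers so far giving numbers within the scatter of each other. On that basis the change from compound 2 to compound 3 is expected to produce no step beyond the scatter in this assay, with a 1.1-fold higher number from compound 2 to compound 3 (0.04 log units; within the scatter) as the estimated shift. Compound 3 is therefore estimated at 30000 nM in this assay, within a range of 12000 nM to 75000 nM.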

Compound 3, concentration for total growth inhibition: 34700 nM
Beside the measured number, compound 3's estimate is 1.2-fold (0.06 log units) below it; the range from low to high includes it.
By their numbers in this assay, from the lowest: compounds 2, 1 and 3 (each within the scatter of the next).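

In this assay, nitro in place of methyl on an aromatic carbon gives a 1.0-fold higher number from compound 1 to compound 3 (0.01 log units; within the scatter), and 2-nitrophenyl in place of 4-methylphenyl on a saturated chain carbon bound to an oxygen on an aromatic ring gives a 1.3-fold higher number from compound 2 to compound 3 (0.10 log units; within the scatter). Among these compounds, the earlier pair compared only two methyl-bearing groups, whereas these steps bring in a group of a different make-up, with nitrogen, oxygen, a double bond outside the aromatic ring and hydrogen-bond acceptors that 4-methylphenyl lacks, and still neither step leaves the scatter. Nothing available explains why the three numbers stay within the scatter of one another.

The compounds shown leave open whether any group at this place can produce a step beyond the scatter, for instance an amine or a carboxylic acid on the aromatic carbon that holds the nitro in compound 3, or a longer chain in place of the benzyl link. They also leave open whether 4-nitrophenyl would stay within the scatter of 2-nitrophenyl, as 4-methylphenyl does of the 2-methylphenyl in compound 1.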